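Swapping a chlorinated ring for a dihydroxy ring

The compounds below may be only part of what the source reports. "The series", "measured", "known", "first", "only" and "open" are said of these compounds alone.

Of the compounds shown here, three sharing one core have been measured in a functional assay on NCI-H460 cells (Homo sapiens) for cytotoxicity, read by MTT assay, with a stated time of 72 h; a higher number here means a weaker inhibitor, a lower number a stronger inhibitor. Compound 1 `CN(C)CCn1cnnc1-c1cc(Oc2ccc(NC(=O)N/N=C/c3ccc(Cl)cc3Cl)cc2F)ccn1` gives 130 nM. Compound 2 `COc1ccc(/C=N/NC(=O)Nc2ccc(Oc3ccnc(-c4nncn4CCN(C)C)c3)c(F)c2)c(OC)c1OC` gives 1790 nM. Compound 3 `CN(C)CCn1cnnc1-c1cc(Oc2ccc(NC(=O)N/N=C/c3ccc(Cl)cc3)cc2F)ccn1` gives 320 nM, which places it second highest of the three numbers: its nearest neighbour is compound 1, with a 2.5-fold higher number from compound 1 to compound 3 (0.39 log units; beyond the scatter), and its furthest is compound 2, with a 5.6-fold lower number from compound 2 to compound 3 (0.75 log units; beyond the scatter).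

Compound 4 `CN(C)CCn1cnnc1-c1cc(Oc2ccc(NC(=O)N/N=C/c3ccc(O)cc3O)cc2F)ccn1` is not yet measured. It differs from compound 3 in one place: 2,4-dihydroxyphenyl in place of 4-chlorophenyl on a carbon with a double bond to nitrogen. The steps already seen bear on this. Putting oxygen-bearing groups on this ring in place of chlorine gave a 14-fold higher number from compound 1 to compound 2 (1.14 log units; beyond the scatter), and the reverse exchange gave a 5.6-fold lower number from compound 2 to compound 3 (0.75 log units; beyond the scatter); removing a single chloro gave a 2.5-fold higher number from compound 1 to compound 3 (0.39 log units; beyond the scatter). Both oxygen-substituted and less chlorinated rings therefore came with higher numbers. For compound 4 a step of a 3.4-fold higher number from compound 3 to compound 4 (0.54 log units; beyond the scatter) toward a higher number is expected in this assay. Compound 4 is estimated at 1100 nM, with a range from 350 nM to 3500 nM.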

Compound 4, half-maximal inhibitory concentration: 11300 nM
Compound 4: the middle estimate sits 10-fold (1.01 log units) below what was measured; measured number outside the range, above it.
By their numbers in this assay, from the lowest: compound 1; then compound 3; then compound 2; then compound 4.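

At this position, oxygen-bearing rings are not interchangeable: the 2,4-dihydroxyphenyl group gives a 6.3-fold higher number from compound 2 to compound 4 (0.80 log units; beyond the scatter), so the rise seen with the 2,3,4-trimethoxyphenyl ring was not the ceiling in this assay. Against the chlorinated rings the change is far larger, with a 35-fold higher number from compound 3 to compound 4 (1.55 log units; beyond the scatter) and an 87-fold higher number from compound 1 to compound 4 (1.94 log units; beyond the scatter), and all four compounds now fall in one order, from 2,4-dichlorophenyl through 4-chlorophenyl and 2,3,4-trimethoxyphenyl to 2,4-dihydroxyphenyl. Nothing available here explains why the number climbs so steeply with this ring.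

The compounds shown leave open whether the hydroxyl groups themselves or simply the loss of chlorine drive this rise. A ring carrying a single hydroxyl, or an amine in place of the hydroxyls, would help separate these two readings.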